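The source may report more compounds than this note shows. Statements on the series, on what has been measured and on what is new or still open speak of the compounds shown alone.

In a functional assay on the whole organism (artery, strain albino) with Rattus norvegicus as the target, with a stated time of 60 min, at a dose of 10 mg/kg by the oral route (on this read-out lower numbers stand for less inhibition and higher numbers for more inhibition at the one dose given (going by the name of the read-out)), three compounds have been measured so far. Compound 1 `COc1ccc(C2N=C(SCc3ccccc3)NC(C)=C2C(=O)Nc2ccc(F)cc2)cc1OC` gives 6.2%, compound 2 `CC1=C(C(=O)Nc2ccc(F)cc2)C(c2ccc([N+](=O)[O-])cc2)N=C(SCc2ccc(Cl)cc2)N1` gives 11.8%, and compound 3 `CC1=C(C(=O)Nc2ccc(Br)cc2)C(c2ccc(Cl)cc2Cl)N=C(SCc2ccccc2)N1` gives 6.7%. Compound 3 stands second highest of the three numbers, nearest to compound 1 and furthest from compound 2, and both gaps fall within the usual scatter of repeated measurements. Compound 4 `CC1=C(C(=O)Nc2ccc(Br)cc2)C(c2ccc(Cl)cc2Cl)N=C(SCc2ccc(F)cc2)N1` has not yet been measured; it differs from compound 3 in one place: fluoro in place of hydrogen on an aromatic carbon. No change of this kind has been measured in this series, and the three measured values sit close together, so no step beyond the scatter is expected. For compound 4 the expected step is a number 0.3 percentage points higher from compound 3 to compound 4 (within the scatter), nothing beyond the scatter. For compound 4 the estimate in this assay is 7%, with a range from 0% to 17%.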

Compound 4, a percentage reported as inhibition, in the whole organism at one dose (the size of the read-out at that dose, not a potency): 16.9%
Estimate against measurement, compound 4: 9.9 percentage points below; the range from low to high includes it.
By their numbers in this assay, from the lowest: compounds 1, 3, 2 and 4 (each within the scatter of the next, the first and the last beyond it).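

In this assay, fluoro in place of hydrogen on an aromatic carbon, para to a large group, gives a number 10.2 percentage points higher from compound 3 to compound 4 (beyond the scatter). Among these compounds, this is the only step read so far, and it shows that this place on the benzyl group can move the number beyond the scatter even though the change adds a single heavy atom. Nothing given here accounts for the step.

On these data alone, whether a trifluoromethyl, a hydroxyl or an amine at this place would move the number in the same direction stays open. As far as these compounds go, it is also open whether fluoro gives a similar step on another compound, since this change rests on a single pair.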